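Benzyl for Phenyl on the Ether Oxygen: Stability Outlook

The source may report more compounds than this note shows. Statements on the series, on what has been measured and on what is new or still open speak of the compounds shown alone.

Compound 3, `COc1cc(OCc2cccc(Oc3ccccc3)c2)c2cc(-c3cn4nc(OC)sc4n3)oc2c1`, stands together with compound 1, `COc1cc(OCc2cccc(COc3ccccc3)c2)c2cc(-c3cn4nc(OC)sc4n3)oc2c1`, at the top of the three numbers in an ADME assay on microsomes from liver (Homo sapiens) for metabolic stability, with a stated time of 10 min; on this read-out lower numbers stand for a less stable compound and higher numbers for a more stable compound: compound 3 gives 86% and compound 1 gives 86%. The smaller compound 2, `COc1nn2cc(-c3cc4c(OC)cccc4o3)nc2s1`, gives 40%, a number well beyond the scatter below the other two. For the measured compounds named here, the only step measured between two compounds that differ in a single place, no change at the digits printed from compound 1 to compound 3 (within the scatter), set phenoxy in the place of phenoxymethyl on the aromatic carbon without any movement beyond the scatter. Compound 4, `COc1cc(OCc2cccc(OCc3ccccc3)c2)c2cc(-c3cn4nc(OC)sc4n3)oc2c1`, is reached from compound 3 by a change on the same side chain: benzyl in place of phenyl on an oxygen on an aromatic ring. Because the earlier step of no change at the digits printed from compound 1 to compound 3 (within the scatter) left the read-out untouched when the same phenyl and oxygen were rearranged on this chain, compound 4 is expected to show no step beyond the scatter, a number 2 percentage points lower from compound 3 to compound 4 (within the scatter). The estimate for compound 4 in this assay is accordingly 84%, with a range expected from 68% to 95%.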

Compound 4, percent of the compound remaining: 85%
For compound 4 the middle estimate is 1 percentage points below the measured one, within the range that was stated.
By their numbers in this assay, from the lowest: compound 2; then compounds 4, 1 and 3 (each within the scatter of the next).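

With a number 1 percentage points lower from compound 3 to compound 4 (within the scatter), benzyl and phenyl on an oxygen on an aromatic ring are not told apart in this assay, and with a number 1 percentage points lower from compound 1 to compound 4 (within the scatter), the same holds for benzyloxy and phenoxymethyl on an aromatic carbon. Together with no change at the digits printed from compound 1 to compound 3 (within the scatter), this gives three side chains, in compound 1, compound 3 and compound 4, that this read-out cannot separate, where the earlier compounds offered only one such pair. Nothing available explains this result.

On these data alone, whether an amine or a carboxylic acid in place of the phenyl on this chain would stay within the scatter remains open. Compound 2 differs from the others in more than one place, so its number cannot be assigned to any single part of the side chain.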